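Swapping a Tertiary Alcohol for a Methyl Ketone

This account rests on a few compounds, and the source may have more. Where it says the series, first, only, none or still open, it means among the compounds named here.

Of the compounds shown here, two sharing one core have been measured in an assay on isolated protein for inhibition of leukotriene B4 receptor 1 (Homo sapiens), tested at 10 uM; a higher number here means more inhibition at the concentration tested (going by the name of the read-out), a lower number less inhibition. Compound 1 `C=CCc1cc(C(C)=O)c(O)cc1OCCCCC#N` ends its chain in a nitrile, and in this assay compound 1 gives 92%. Compound 2 `C=CCc1cc(C(C)=O)c(O)cc1OCCCCCC(C)(C)O` carries a 2-hydroxy-2-methylpropyl group where compound 1 carries the cyano group, and in this assay compound 2 gives 98%, the highest of the two numbers, though the step of a number 6 percentage points higher from compound 1 to compound 2 (within the scatter) lies within the scatter.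

Compound 3 `C=CCc1cc(C(C)=O)c(O)cc1OCCCCCC(C)=O` has not yet been measured. For the measured compounds named here, it differs from compound 2 in one place: acetyl in place of 1-hydroxy-1-methylethyl on a saturated chain carbon, five bonds along the chain from an oxygen on an aromatic ring The only measured step, from compound 1 to compound 2, exchanged a different group and stayed within the scatter, so it bears on this change only loosely. Since compound 2 already stands at 98%, the expected step of a number 5 percentage points lower from compound 2 to compound 3 (within the scatter) is none beyond the scatter. Compound 3 is therefore estimated at 93%, with a range from 80% to 100%.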

Compound 3, a percentage reported as inhibition, at one concentration (the size of the read-out at that concentration, not a potency): 98%
The estimate for compound 3 lay 5 percentage points below the measured number, within the range that was stated.
By their numbers in this assay, from the lowest: compounds 1, 2 and 3 (each within the scatter of the next).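

In this assay, the step of no change at the digits printed from compound 2 to compound 3 (within the scatter) shows that, on a saturated chain carbon, five bonds along the chain from an oxygen on an aromatic ring, acetyl can stand in place of 1-hydroxy-1-methylethyl without a difference that can be told apart from the scatter, even though acetyl has 0 hydrogen-bond donors and the group it replaces has 1. The step of a number 6 percentage points higher from compound 1 to compound 3 (within the scatter) puts 2-oxopropyl in place of cyano and also stays within the scatter, so the nitrile, tertiary alcohol and ketone chain ends of these three compounds cannot be separated by this read-out. Nothing available here accounts for this result or tests why these chain ends read alike.

On these data alone, each number is the size of the inhibition at one concentration and not a potency, so whether these three compounds would separate at lower concentrations stays open. Also open, as far as these compounds go, is what a different group would give, such as an amine or a carboxylic acid at the end of the chain, or a longer chain carrying the same acetyl.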